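A few compounds are considered here, and "the series" means these few. Any claim that something is new, unique, unknown or untested is made for them only; others in the source may bear on it.

Measured so far in a functional assay on cells for antagonist activity at taste receptor type 2 member 8 (Homo sapiens), read by FLIPR and calcium flux, with a stated time of 100 s; on this read-out lower numbers stand for stronger inhibition and higher numbers for weaker inhibition:
compound 1 `Cc1noc(C)c1Cn1cc(NC(=O)c2ccccn2)cn1` gives 2300 nM
compound 2 `COc1cccc(C(=O)Nc2cnn(Cc3c(C)noc3C)c2)n1` gives 700 nM
compound 3 `COc1ccc(C(=O)Nc2cnn(Cc3c(C)noc3C)c2)cc1` gives 700 nM

Compound 4 `COc1ccc(C(=O)Nc2cnn(Cc3c(C)noc3C)c2)cc1OC` is not yet measured. It differs from compound 3 by methoxy in place of hydrogen on an aromatic carbon. The same change, on another core, runs from compound 1 to compound 2: methoxy in place of hydrogen on an aromatic carbon, with a 3.3-fold lower number from compound 1 to compound 2 (0.52 log units; beyond the scatter). The two cores differ by 4-methoxyphenyl in place of pyridin-2-yl on a carbonyl carbon. The places are not identical: in compound 1 the entering group sits on a six-membered aromatic ring with 1 nitrogen, next to the ring nitrogen; in compound 3 on a six-membered aromatic ring of carbon only, ortho to a methoxy group; both meta to a large group. It is therefore the same kind of change, not the same one. Between compound 2 and compound 3 there is no change at the digits printed from compound 2 to compound 3 (within the scatter). A smaller step is expected here, a 1.4-fold lower number from compound 3 to compound 4 (0.15 log units; within the scatter), because a 3.3-fold lower number from compound 1 to compound 2 (0.52 log units; beyond the scatter) was made at a different place. Compound 4 is expected to give about 500 nM, between 150 nM and 1500 nM, in this assay.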

Compound 4, half-maximal inhibitory concentration: 1000 nM
Compound 4: middle estimate off by 2.0-fold (0.30 log units), on the low side; the range from low to high includes it.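

In this assay, methoxy in place of hydrogen on an aromatic carbon gives a 1.4-fold higher number from compound 3 to compound 4 (0.15 log units; within the scatter), so the gain seen on the core of compound 1 does not reappear on the core of compound 3. The two steps differ: the same change on two cores in this assay, a 3.3-fold lower number (0.52 log units; beyond the scatter) from compound 1 to compound 2 and a 1.4-fold higher number (0.15 log units; within the scatter) from compound 3 to compound 4, 4.7-fold (0.67 log units) apart, beyond the scatter of two such steps This shows that the size of this step does not carry over between these two cores, but with one pair on each core and the methoxy entering at a different place in each, it does not separate the role of the core from that of the place.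

Still open, as far as these compounds go, is whether methoxy entering at one and the same place gives matching steps on both cores. Also open, from the compounds shown here alone, is how a longer chain such as ethoxy, an amine or a carboxylic acid would read in place of the same hydrogen.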